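The compounds below may be only part of what the source reports. "The series", "measured", "known", "first", "only" and "open" are said of these compounds alone.

Of the compounds shown here, three have so far been tested in a functional assay on T47D cells (Homo sapiens) for cytotoxicity, read by sulforhodamine B assay, with a stated time of 48 h, tested at 10 uM; on this read-out higher numbers stand for a weaker effect at the one concentration tested and lower numbers for a stronger effect. Compound 1 `COc1ccc(-c2cc(/C=C/C(=O)c3ccc(N)cc3)[nH]n2)cc1` gives -1% in this assay. Compound 3 `COc1ccc(-c2cc(/C=C/C(=O)c3ccc(N)cc3)[nH]n2)cc1OC` carries one more group: the change is methoxy in place of hydrogen on an aromatic carbon, and it moves the read-out by a number 29 percentage points higher from compound 1 to compound 3 (beyond the scatter), so that compound 3 gives 28%. Compound 2 `COc1ccc(C(=O)/C=C/c2cc(-c3cc(OC)c(OC)c(OC)c3)n[nH]2)cc1OC` is built on a different core, and the difference between the two cores is not broken down here. In this assay compound 2 gives -42%, the lowest of the three numbers and therefore the strongest effect at the one concentration tested.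

Compound 4 `COc1cc(C(=O)/C=C/c2cc(-c3cc(OC)c(OC)c(OC)c3)n[nH]2)cc(OC)c1OC` has not yet been measured. It differs from compound 2 by methoxy in place of hydrogen on an aromatic carbon. Among the compounds with values here, this is the same kind of change as the one leading to compound 3, but not the same: around the place where the new group enters, compound 4 has it also meta to a methoxy group, which was not so in the earlier change. Within the data shown here, only one such step has been seen, and it came on a different core. If the new step resembles the earlier one, compound 4 would be expected to show a weaker effect than compound 2. The expected step is a number 22 percentage points higher from compound 2 to compound 4 (beyond the scatter), and this expectation rests on the measured step of a number 29 percentage points higher from compound 1 to compound 3 (beyond the scatter). Compound 4 is estimated to give -20% in this assay, with a range from -60% to 20%.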

Compound 4, a percentage reported as activity, at one concentration (the size of the read-out at that concentration, not a potency): -82%
For compound 4 the middle estimate is 62 percentage points above the measured one, outside the stated range (below it).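

In this assay, putting a methoxy in place of hydrogen on an aromatic carbon gave a number 40 percentage points lower from compound 2 to compound 4 (beyond the scatter), so on this core the effect at the one concentration tested became stronger, whereas on the core of compound 1 the same kind of change made it weaker. The change therefore does not carry over from one core to the other in this series, in size or in direction: the same change on two cores in this assay, a number 29 percentage points higher (beyond the scatter) from compound 1 to compound 3 and a number 40 percentage points lower (beyond the scatter) from compound 2 to compound 4, 69 percentage points apart, beyond the scatter of two such steps What this does not show is the reason for the split: the two steps differ in their core and also in the surroundings of the new group, which in compound 4 is also meta to a methoxy group, and a single step on each core cannot separate these two differences.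

The compounds shown leave open whether a further step on either core would keep the direction seen there, and whether a different group at the same place, such as an ethoxy group, a fluorine or a carboxylic acid, would follow the methoxy step. They also leave open whether the stronger or weaker effects seen here would hold at other concentrations: each compound is described at only one concentration.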